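This account rests on a few compounds, and the source may have more. Where it says the series, first, only, none or still open, it means among the compounds named here.

Measured so far:
compound 1, `CCOC(=O)c1cnc(SC)nc1NN1C(=O)C=C(C)C1=O`, 200 nM
compound 2, `CCOC(=O)c1cnc(-c2cc(Cl)nc(Cl)c2)nc1NN1C(=O)C=C(C)C1=O`, 2000 nM

Both compounds share one core and differ only in the group on an aromatic carbon between two ring nitrogen atoms. In a functional assay on Jurkat cells for inhibition of nuclear factor NF-kappa-B complex (Homo sapiens) (on this read-out lower numbers stand for stronger inhibition and higher numbers for weaker inhibition), compound 1 gives 200 nM, and compound 2 gives 2000 nM, so compound 2 stands at the highest of the two numbers seen so far; the step of a 10-fold higher number from compound 1 to compound 2 (1.00 log units; beyond the scatter) separates it from compound 1.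

Compound 3, `CCOC(=O)c1cnc(-c2csc(C)n2)nc1NN1C(=O)C=C(C)C1=O`, has not yet been measured. It differs from compound 2 in one place: 2-methyl-1,3-thiazol-4-yl in place of 2,6-dichloropyridin-4-yl on an aromatic carbon. Among the compounds with values here, the only measured step that bears on this change is a 10-fold higher number from compound 1 to compound 2 (1.00 log units; beyond the scatter), which shows that exchanging the methylsulfanyl for an aromatic ring at this position raised the number. Compound 3 keeps an aromatic ring there, though a smaller one with a different set of hetero atoms, so no firm direction can be read from a single step. He therefore expects compound 3 to fall between the two measured numbers, closer to compound 2, estimated at 1000 nM with a range of 300 nM to 4000 nM, which means an expected step of a 2.0-fold lower number from compound 2 to compound 3 (0.30 log units; within the scatter).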

Compound 3, half-maximal inhibitory concentration: 8000 nM
For compound 3 the middle estimate is 8.0-fold (0.90 log units) below the measured one; measured number above the stated range.
By their numbers in this assay, from the lowest: compound 1; then compound 2; then compound 3.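

In this assay, the aromatic groups at this position are not interchangeable: 2-methyl-1,3-thiazol-4-yl in place of 2,6-dichloropyridin-4-yl gives a 4.0-fold higher number from compound 2 to compound 3 (0.60 log units; beyond the scatter), so the identity of the ring matters as well as the presence of one. Set against methylsulfanyl, the same thiazole group gives a 40-fold higher number from compound 1 to compound 3 (1.60 log units; beyond the scatter), a larger step than the one seen with the dichloropyridine, and among these three compounds both aromatic groups give higher numbers than methylsulfanyl, with no compound going against that. Nothing available here accounts for these differences.

The two aromatic groups differ at once in ring size, in their hetero atoms and in their chlorine or methyl groups, so these compounds cannot show which of those differences goes with the higher number in compound 3. Also open, going by these compounds, is how an amine such as dimethylamino, an unsubstituted phenyl ring or a longer sulfur-linked chain such as ethylsulfanyl would compare with methylsulfanyl on an aromatic carbon at this position.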